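From a Trimethoxyphenyl Hydrazone to a Hydroxyphenyl One

The compounds below may be only part of what the source reports. "The series", "measured", "known", "first", "only" and "open" are said of these compounds alone.

Compound 1 `CCOC(=O)c1ccc(OCc2cc(OC)c(OC)c(OC)c2)cc1`: > 100 ug/mL
Compound 2 `COc1cc(COc2ccc(C(=O)N/N=C/c3cc(Br)cc(Cl)c3O)cc2)cc(OC)c1OC`: > 100 ug/mL
Compound 3 `COc1cc(/C=N/NC(=O)c2ccc(OCc3cc(OC)c(OC)c(OC)c3)cc2)cc(OC)c1OC`: > 100 ug/mL

In a physicochemical assay, with a stated time of 30 min (on this read-out lower numbers stand for stronger inhibition and higher numbers for weaker inhibition), compound 1 gives > 100 ug/mL, which is a limit of the assay rather than a number. Compound 2 likewise gives > 100 ug/mL, again a limit. Compound 3 gives > 100 ug/mL, also a limit. Compound 3 thus sits at the limit of > 100 ug/mL in this assay, at which 3 of the 3 values shown sit, alongside every other measured compound, and no order among the three can be read. Among the measured compounds shown here, the only step between neighbours, a step that the two limits leave unreadable from compound 2 to compound 3, is left unreadable by the two limits.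

Compound 4 `COc1cc(COc2ccc(C(=O)N/N=C/c3ccccc3O)cc2)cc(OC)c1OC` is yet to be measured in this assay. It differs from compound 3 in one place: 2-hydroxyphenyl in place of 3,4,5-trimethoxyphenyl on a carbon with a double bond to nitrogen. For the measured compounds named here, the single measured step concerns the same carbon with a double bond to nitrogen, but it carries no size, so no direction can be expected beyond the scatter; the plainest expectation is that compound 4 stays at the limit. For compound 4 the estimate in this assay is 100 ug/mL, with a range from 30 ug/mL to 300 ug/mL. The step this estimate implies, a number no higher from compound 3 to compound 4 (the limit leaves the size open), is expected to lie within the scatter.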

Compound 4, half-maximal inhibitory concentration: > 100 ug/mL
Compound 4 was reported as a limit (the forecaster's own chance of this, stated with the estimate: 70%); the middle value lies on the limit itself.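

Compound 4 stands at a limit in this assay, as do compound 1, compound 2 and compound 3, so no step among these four compounds can be read: the limit of > 100 ug/mL in this assay, at which 4 of the 4 values shown sit.

The compounds shown leave open whether any change on the carbon with a double bond to nitrogen, or on the carbonyl carbon, alters inhibition at all.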